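The compounds below may be only part of what the source reports. "The series", "measured", "known", "first", "only" and "open" are said of these compounds alone.

Working notes on the series. Compound 3 `CC#CCn1c(N2CCC[C@@H](N)C2)cc(=O)n(Cc2cc(C(=O)O)ccc2F)c1=O` carries a carboxy group on the benzyl arm. In an assay on isolated protein for inhibition of Dipeptidyl peptidase 9 (Homo sapiens), read by fluorescence, with stated times of 15 min and 20 min (a higher number here means a weaker inhibitor, a lower number a stronger inhibitor), compound 3 gives > 100 nM, which is a limit of the assay and not a number. Compound 1 `CC#CCn1c(N2CCC[C@@H](N)C2)cc(=O)n(Cc2cc(C(=O)OC)ccc2Br)c1=O` gives > 100 nM in this assay, again a limit rather than a number. Compound 2 `CC#CCn1c(N2CCC[C@@H](N)C2)cc(=O)n(Cc2cccc(C(=O)O)c2Br)c1=O` has "not determined" (no result reported) in this assay. Compound 3 therefore stands at the limit of > 100 nM in this assay, at which 2 of the 3 values shown sit, and no numbered value exists anywhere in the set, so no measured step can be read from the series.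

Compound 4 `CC#CCn1c(N2CCC[C@@H](N)C2)cc(=O)n(Cc2cc(C(=O)OC)ccc2F)c1=O` differs from compound 3 by methyl in place of hydrogen on an oxygen next to a carbonyl group. Compound 1 carries the methoxycarbonyl group and sits at the limit of > 100 nM in this assay, at which 2 of the 3 values shown sit, just as compound 3 does, which gives no sign that the methyl changes anything readable. The expected step that the limit leaves unreadable from compound 3 to compound 4 is accordingly none beyond the scatter. For compound 4 the estimate is 300 nM, within 100 nM to 3000 nM, and the assay is expected most likely to report only a limit again.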

Compound 4, half-maximal inhibitory concentration: > 100 nM
Compound 4: a limit, no number; the forecaster's own chance of this, stated with the estimate: 80%; the middle value lies beyond the limit too.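

No new step can be read between compound 4 and compound 3 or compound 1, as all three give a limit and not a number in this assay: the limit of > 100 nM in this assay, at which 3 of the 4 values shown sit.

The compounds shown leave open how far each lies beyond that limit, and whether either single change alters inhibition at all.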